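A few compounds are considered here, and "the series" means these few. Any claim that something is new, unique, unknown or untested is made for them only; others in the source may bear on it.

Measured compounds, all in a functional assay on HL-60 cells (Homo sapiens) for cytotoxicity, read by WST assay, with a stated time of 48 h; on this read-out lower numbers stand for an effect already at smaller amounts and higher numbers for an effect only at larger amounts of compound:

Compound 1 `O=C1OC[C@H](Cc2ccccc2)[C@H]1Cc1ccccc1F` gives 72000 nM.
Compound 2 `O=C1OC[C@H](Cc2ccccc2)[C@H]1Cc1cccc(O)c1` gives > 100000 nM, which is a limit of the assay and not a number.
Compound 3 `Fc1ccccc1C[C@H]1COC[C@@H]1Cc1ccc(Cl)c(Cl)c1` gives 51000 nM.

Of the two numbers given, compound 3 has the lower one, and its gap to compound 1 lies within the scatter, so no order between them is claimed. The difference between the core of compound 1 and the core of compound 3 is not broken down here.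

Within the core of compound 1 there is one measured step, (3-hydroxyphenyl in place of 2-fluorophenyl on a saturated chain carbon bound to a saturated ring carbon). It made an at least 1.3-fold higher number from compound 1 to compound 2 (0.14 log units; that floor lies within the scatter); that the step has only a floor follows from the limit of > 100000 nM in this assay, at which 1 of the 3 values shown sits.

Compound 4 `Oc1cccc(C[C@H]2COC[C@@H]2Cc2ccc(Cl)c(Cl)c2)c1` is not yet measured. It differs from compound 3 by 3-hydroxyphenyl in place of 2-fluorophenyl on a saturated chain carbon bound to a saturated ring carbon, the same change made on the other core, with the place described in the same words.

A step of a 2.0-fold higher number from compound 3 to compound 4 (0.29 log units; within the scatter) in this assay is expected from compound 3 to compound 4, resting on the step from compound 1 to compound 2 of an at least 1.3-fold higher number from compound 1 to compound 2 (0.14 log units; that floor lies within the scatter). Compound 4 is estimated at 100000 nM, between 55000 nM and 200000 nM, with a real chance that only a limit is reported.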

Compound 4, half-maximal effective concentration: 31000 nM
Compound 4: the middle estimate sits 3.2-fold (0.51 log units) above what was measured; measured number below the stated range.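

In this assay, 3-hydroxyphenyl in place of 2-fluorophenyl on a saturated chain carbon bound to a saturated ring carbon gives a 1.6-fold lower number from compound 3 to compound 4 (0.22 log units; within the scatter), so on the core of compound 3 this step does not stand out from the scatter. Set beside the step on the core of compound 1, the result does not settle whether the change behaves alike on both cores: the same change on two cores in this assay, an at least 1.3-fold higher number (0.14 log units; that floor lies within the scatter) from compound 1 to compound 2 and a 1.6-fold lower number (0.22 log units; within the scatter) from compound 3 to compound 4; the limit leaves it open whether they differ. Among the compounds shown here, the pair therefore shows neither that the step carries over from one core to the other nor that it fails to, and the only reading on the core of compound 1 is a floor tied to an assay limit: the limit of > 100000 nM in this assay, at which 1 of the 4 values shown sits.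

The compounds shown leave open whether a different group on this chain carbon, such as an amine or a carboxylic acid, would give a step beyond the scatter on either core. From the compounds shown here alone, what the difference between the core of compound 1 and the core of compound 3 contributes on its own also stays open.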